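The source may hold more compounds than are shown below. What is called first, only, known or untested is meant among the compounds shown, and "the series" means these compounds.

Compound 1 `O=C(O)CCc1cc(F)c(OCc2c(-c3ccc(Cl)cc3)noc2C(F)(F)F)c(F)c1`: 99.9%
Compound 2 `O=C(O)CCc1cc(F)c(OCc2c(-c3ccccc3)noc2C(F)(F)F)c(F)c1`: 99.5%

These two compounds were measured in an ADME assay on a cell-free system (plasma, Mus musculus) for protein binding, and compound 2 has the higher unbound fraction of the pair. Compound 3 `CCc1ccc(-c2noc(C(F)(F)F)c2COc2c(F)cc(CCC(=O)O)cc2F)cc1` follows from compound 2 through (ethyl in place of hydrogen on an aromatic carbon), with ethyl in place of hydrogen on an aromatic carbon, turning phenyl to 4-ethylphenyl. Within the data shown here, only one measured step bears on this change: a 5.0-fold higher unbound fraction from compound 1 to compound 2 (0.70 log units; beyond the scatter), which puts hydrogen in place of chloro on an aromatic carbon. Among the measured compounds shown here, that single step is thin evidence, and no measured compound carries ethyl. Read in reverse, it suggests that a group replacing hydrogen may lower the unbound fraction, so a modest drop, probably no larger than that step, is expected in this assay. The expected step is a 2.5-fold lower unbound fraction from compound 2 to compound 3 (0.40 log units; beyond the scatter). For compound 3 the estimate is 99.8%, with an expected range from 99.4% to 99.95%.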

Compound 3, plasma protein binding: 99.9%
Beside the measured number, compound 3's estimate is 2.0-fold (0.30 log units) (unbound fraction) above it; measured number inside the range.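

At this position, para to a large group, ethyl now joins chloro as a second group that lowers the free share: in this assay putting ethyl in place of hydrogen gives a 5.0-fold lower unbound fraction from compound 2 to compound 3 (0.70 log units; beyond the scatter) and so the effect seen earlier is not confined to chloro. Ethyl and chloro are not separated here, as the exchange between them gives no change at the digits printed from compound 1 to compound 3 (within the scatter) and leaves compound 2, with hydrogen, as the one with the highest unbound fraction. Nothing at hand explains this behaviour at the position.

From the compounds shown here alone, whether a group as small as methyl or fluoro would already bring the same drop, or whether an amine or a hydroxyl would move the unbound fraction back towards that of compound 2, stays open. So does whether a longer chain such as propyl would lower the unbound fraction in this assay any further than ethyl does.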